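This account rests on a few compounds, and the source may have more. Where it says the series, first, only, none or still open, it means among the compounds named here.

Measured compounds in a functional assay on B16-F10 cells (Mus musculus) for inhibition, read by MTT assay, with a stated time of 48 h; on this read-out higher numbers stand for weaker inhibition and lower numbers for stronger inhibition:

compound 1 `CCCCCCCCNC(=O)/C=C/c1c(/C=C/c2ccc(OC)cc2)cc(OC)cc1OC`: 8060 nM
compound 2 `C#CCNC(=O)/C=C/c1c(/C=C/c2ccc(OC)cc2)cc(OC)cc1OC`: 8280 nM
compound 3 `COc1ccc(/C=C/c2cc(OC)cc(OC)c2/C=C/C(=O)NC(C)C)cc1`: 4020 nM

Compound 3 holds the lowest of the three numbers in this assay. Its nearest neighbour is compound 1, with a 2.0-fold lower number from compound 1 to compound 3 (0.30 log units; within the scatter), a step that sits within the scatter. The gap to compound 2, a 2.1-fold lower number from compound 2 to compound 3 (0.31 log units; beyond the scatter), is the only one in the set that reaches beyond the scatter, and only modestly. Between compound 1 and compound 2 the step is a 1.0-fold higher number from compound 1 to compound 2 (0.01 log units; within the scatter).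

Compound 4 `CCCCN(CCCC)C(=O)/C=C/c1c(/C=C/c2ccc(OC)cc2)cc(OC)cc1OC` is not yet measured. It differs from compound 3 as follows: dibutylamino in place of isopropylamino on a carbonyl carbon. All three measured steps change the group on the amide-type nitrogen, so all bear on this one, and none of them moved the number by much. Going by the values given here, no measured step removes the hydrogen-bond donor, so that part of the change is uncovered. The expectation is therefore a small step in this assay, if anything toward a higher number, a 1.7-fold higher number from compound 3 to compound 4 (0.24 log units; within the scatter). Compound 4 is estimated at 7000 nM, with a range from 3000 nM to 16000 nM.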

Compound 4, half-maximal inhibitory concentration: 9030 nM
Beside the measured number, compound 4's estimate is 1.3-fold (0.11 log units) below it, and the stated range covers the measured number.
By their numbers in this assay, from the lowest: compounds 3, 1, 2 and 4 (each within the scatter of the next, the first and the last beyond it).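

In this assay, going by these compounds alone, dibutylamino on the carbonyl carbon is the first group without the amide hydrogen, and it gives a 2.2-fold higher number from compound 3 to compound 4 (0.35 log units; beyond the scatter), a modest step beyond the scatter and the first such step away from isopropylamino that also removes a hydrogen-bond donor. Loss of that hydrogen does not separate the group from those that keep it: octylamino gives a 1.1-fold higher number from compound 1 to compound 4 (0.05 log units; within the scatter) and propargylamino gives a 1.1-fold higher number from compound 2 to compound 4 (0.04 log units; within the scatter), both within the scatter, so among these compounds only isopropylamino stands apart from dibutylamino. No measurement at hand accounts for these steps.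

Compound 4 changes the amide hydrogen and the size of the group together, so the two remain unseparated in this series. Also open, going by these compounds, is how dimethylamino, a morpholine ring or a chain ending in a carboxylic acid would read at this carbonyl carbon.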